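The compounds below may be only part of what the source reports. "The series", "measured", "known", "first", "only" and "open" are said of these compounds alone.

Measured so far:
- Compound 1 `CCCCN(CC)c1nc(C)nc2c1nnn2-c1ccc(C(C)C)cc1Br`: 26.5%
- Compound 2 `CCC(COC)Nc1nc(C)nc2c1nnn2-c1ccc(C(C)C)cc1Br`: 21%

In an in vivo ADME assay on the whole organism (Rattus norvegicus) for pharmacokinetics (a higher number here means that a larger share of the oral dose reaches the circulation, a lower number that a smaller share of the oral dose reaches the circulation), compound 2 gives 21%, which cannot be told apart from compound 1 at 26.5%. Compound 3 `CCC(COC)Oc1nc(C)nc2c1nnn2-c1ccc(C(C)C)cc1Br` has not been measured. It carries 1-(methoxymethyl)propoxy in place of (1-(methoxymethyl)propyl)amino on an aromatic carbon. Within the data shown here, no measured step makes this same exchange. Among the measured compounds shown here, the only guide is a different swap at that place, a number 5.5 percentage points lower from compound 1 to compound 2 (within the scatter). A change of similar modest size is therefore expected, with an estimated step of a number 3 percentage points higher from compound 2 to compound 3 (within the scatter). For compound 3 the estimate is 24%, with an expected range from 10% to 42%.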

Compound 3, oral bioavailability: 6%
Compound 3: middle estimate off by 18 percentage points, on the high side, outside the stated range (below it).
By their numbers in this assay, from the lowest: compound 3; then compounds 2 and 1 (each within the scatter of the next).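

In this assay, the link between this side chain and the aromatic carbon matters: 1-(methoxymethyl)propoxy in place of (1-(methoxymethyl)propyl)amino brings a number 15 percentage points lower from compound 2 to compound 3 (beyond the scatter) and so separates two groups of equal heavy-atom count. Replacing butyl(ethyl)amino with the same group brings a number 20.5 percentage points lower from compound 1 to compound 3 (beyond the scatter) and so also clears the scatter, unlike the earlier exchange between the two amino groups. No measurement at hand explains this fall. Still open, on these data alone, is how a shorter ethoxy group would compare with 1-(methoxymethyl)propoxy at this place. A cyclic amine such as morpholine is also untested here.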